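Toward compound 4: an aryl group replaces the propyl chain

A few compounds are considered here, and "the series" means these few. Any claim that something is new, unique, unknown or untested is made for them only; others in the source may bear on it.

The shared core, carrying a methylated five-membered ring with a hydroxymethyl group, appears in compound 1 `CN1OC(n2cc3ccoc3nc2=O)CC1CO`, compound 2 `CCCc1cc2cn(C3CC(CO)N(C)O3)c(=O)nc2o1` and compound 3 `CCCCCc1ccc(-c2cc3cn(C4CC(CO)N(C)O4)c(=O)nc3o2)cc1`. In an ADME assay on Vero cells (Chlorocebus sabaeus), read by MTT assay (on this read-out higher numbers stand for lower toxicity in this test and lower numbers for higher toxicity in this test), compound 1 gives 125000 nM, compound 2 gives 31300 nM and compound 3 gives 3000 nM. Compound 2 stands second highest of the three, between the other two. The step of a 4.0-fold lower number from compound 1 to compound 2 (0.60 log units; beyond the scatter) shows that adding the propyl chain lowered the number. Compound 4 `COc1ccc(-c2cc3cn(C4CC(CO)N(C)O4)c(=O)nc3o2)cc1` differs from compound 2 by 4-methoxyphenyl in place of propyl on an aromatic carbon. Within the data shown here, no measured step covers exactly this change; the only bearing step is that from compound 1 to compound 2, which was modest, while compound 3, which also carries an aryl group at the same place, shows a lower number than compound 2. Compound 4 is therefore expected to move downward by a 3.9-fold lower number from compound 2 to compound 4 (0.59 log units; beyond the scatter), landing between compound 2 and compound 3. The estimate for compound 4 in this assay is 8000 nM, with a range from 3000 nM to 25000 nM.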

Compound 4, half-maximal cytotoxic concentration: 62500 nM
The estimate for compound 4 lay 7.8-fold (0.89 log units) below the measured number, outside the stated range (above it).
By their numbers in this assay, from the lowest: compound 3; then compounds 2, 4 and 1 (each within the scatter of the next, the first and the last beyond it).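

In this assay, an aryl group at this place does not by itself bring the number down: 4-methoxyphenyl in place of propyl gives a step within the scatter (a 2.0-fold higher number from compound 2 to compound 4 (0.30 log units; within the scatter)), and so does 4-methoxyphenyl in place of hydrogen (a 2.0-fold lower number from compound 1 to compound 4 (0.30 log units; within the scatter)). The large step between the two aryl compounds (a 21-fold higher number from compound 3 to compound 4 (1.32 log units; beyond the scatter)) shows that the low number of compound 3 goes with the pentyl group on its aryl ring, not with the aryl ring alone. Nothing available explains why these two groups differ so much.

With only methoxy and pentyl on the aryl ring, these compounds do not show how the number follows the group held there. An ethyl or butyl chain, an amine or a carboxylic acid at that place would test this.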